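The source may hold more compounds than are shown below. What is called first, only, known or untested is meant among the compounds shown, and "the series" means these compounds.

Of the compounds shown here, three have so far been measured in a functional assay on MM1 cells (Homo sapiens) for antiproliferative activity, read by MTT assay, with a stated time of 72 h; on this read-out lower numbers stand for stronger inhibition and higher numbers for weaker inhibition. Compound 1 `COC(=O)C[C@H](NC(=O)/C(C#N)=C/c1cccc(Br)n1)c1ccccc1` gives 3100 nM in this assay. For compound 2 `CCC[C@H](NC(=O)/C(C#N)=C/c1ccc(O)c(Br)c1)c1ccccc1` this assay reports only a limit, > 10000 nM. Compound 3 `CCC(NC(=O)/C(C#N)=C/c1ccc(-c2cccc([N+](=O)[O-])c2)o1)c1ccccc1` likewise comes back at a limit in this assay, > 10000 nM, so no number is known for it. Compound 3 thus stands at the limit of > 10000 nM in this assay, at which 2 of the 3 values shown sit, and only compound 1 gives a number at all.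

Compound 4 `Cc1ccc(CNC(=O)/C(C#N)=C/c2ccc(-c3cccc([N+](=O)[O-])c3)o2)o1` has not yet been measured. It differs from compound 3 in one place: (5-methylfuran-2-yl)methyl in place of 1-phenylpropyl on an amide-type nitrogen. Among the compounds with values here, no measured pair separates the two ends of this change, so its size in this assay cannot be read from the other compounds. Within the data shown here, compound 3 offers only a limit, and nothing among the measured compounds points to a gain beyond the scatter for this change, so the step from compound 3 to compound 4 is expected to be an at least 1.1-fold lower number from compound 3 to compound 4 (0.04 log units; that floor lies within the scatter), that is none that can be told from the scatter. Compound 4 is therefore expected to give about 9000 nM in this assay, within a range of 3000 nM to 30000 nM, with a fair chance that it too is reported only as a limit.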

Compound 4, half-maximal inhibitory concentration: > 10000 nM
Compound 4: only a limit was reported (the forecaster's own chance of this, stated with the estimate: 65%); middle value at least 1.1-fold (0.04 log units) away from the limit.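

In this assay compound 4 returns only a limit, > 10000 nM. Compound 3 also stands at a limit, so no step can be read between compound 3 and compound 4. The compounds shown leave open whether the core shared by compound 3 and compound 4 can give a true number in this assay with any group on the amide-type nitrogen.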